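The compounds below may be only part of what the source reports. "The series", "measured", "known", "first", "only" and "open" are said of these compounds alone.

Measured so far:
Compound 1 `CCC/C=C\C(=O)Nc1cc(Nc2nc(C)cc(-c3cn(C)c4ccccc34)n2)c(OC)cc1N(C)CCN(C)C` gives 365 nM in a functional assay on HepG2 cells (Homo sapiens) for antiproliferative activity, read by MTT assay, with a stated time of 72 h; a higher number here means a weaker inhibitor, a lower number a stronger inhibitor.
Compound 2 `CC/C=C\C(=O)Nc1cc(Nc2nc(C)cc(-c3cn(C)c4ccc(F)cc34)n2)c(OC)cc1N(C)CCN(C)C` gives 11000 nM in this assay.

Of the two numbers at hand, compound 2 holds the highest, which in this assay means the weaker of the two inhibitors; its nearest neighbour is compound 1, and the gap between the two values lies well beyond the scatter of repeated measurements. For the measured compounds named here, the two compounds differ in more than one place, so no single step between them can be read off.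

Compound 3 `CCC/C=C\C(=O)Nc1cc(Nc2nc(C)cc(-c3cn(C)c4ccc(F)cc34)n2)c(OC)cc1N(C)CCN(C)C` has not yet been measured. It differs from compound 2 in one place: methyl in place of hydrogen on a saturated chain carbon, two bonds along the chain from a double-bonded chain carbon. In other words, the chain on the amide grows by one carbon, from but-1-en-1-yl to pent-1-en-1-yl.

Going by the values given here, the data give no measured step for this change on its own. Among the compounds with values here, the longer chain is the one found in compound 1, whose value in this assay is far lower than that of compound 2, but compound 1 also differs elsewhere, so that comparison is only a hint. A moderate move toward a lower number is therefore expected, with wide uncertainty. For compound 3 the estimate in this assay is 3500 nM, within a range from 700 nM to 15000 nM, which amounts to an expected step of a 3.1-fold lower number from compound 2 to compound 3 (0.50 log units; beyond the scatter).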

Compound 3, half-maximal inhibitory concentration: 12100 nM
Estimate against measurement, compound 3: 3.5-fold (0.54 log units) below; measured number inside the range.
By their numbers in this assay, from the lowest: compound 1; then compounds 2 and 3 (each within the scatter of the next).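

In this assay, replacing but-1-en-1-yl with pent-1-en-1-yl on the amide of the fluoro-bearing compounds gives a 1.1-fold higher number from compound 2 to compound 3 (0.04 log units; within the scatter) and so produces no difference that can be told from ordinary repeat-to-repeat variation, which means this added methyl on the saturated chain carbon does not register here. The large gap between the first two compounds now has a clearer reading: with the pent-1-en-1-yl chain held the same, fluoro in place of hydrogen on an aromatic carbon goes with a 33-fold higher number from compound 1 to compound 3 (1.52 log units; beyond the scatter) in this assay, a large loss of activity from one small change. No measurement at hand gives a reason for either result.

Going by these compounds, it remains open whether the chain length would matter just as little on a compound without the fluoro group, since the but-1-en-1-yl chain appears here only together with fluoro. Also unresolved is whether another group at the same aromatic carbon, such as chloro or methoxy, would bring a loss like that seen with fluoro, and whether a longer chain such as hex-1-en-1-yl would still leave the number unmoved.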